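The compounds below may be only part of what the source reports. "The series", "measured", "known", "first", "only" and "open" are said of these compounds alone.

Two compounds share one core and differ only in what sits on one aromatic ring. Compound 1 `O=C(OCc1ccccc1)N1CCN(C(=S)SCc2cn(Cc3ccc(Cl)c(Cl)c3)nn2)CC1` gives 10600 nM in a functional assay on MCF7 cells (Homo sapiens) for inhibition, read by MTT assay, with a stated time of 72 h; a lower number here means a stronger inhibitor, a higher number a weaker inhibitor. Among the measured compounds shown here, compound 2 `O=C(OCc1ccccc1)N1CCN(C(=S)SCc2cn(Cc3ccc(Cl)cc3)nn2)CC1` gives 27500 nM in this assay, the highest of the two numbers so far, and the step of a 2.6-fold higher number from compound 1 to compound 2 (0.41 log units; beyond the scatter) shows that taking away one chloro weakens inhibition beyond the scatter. Compound 3 `COc1cc(Cn2cc(CSC(=S)N3CCN(C(=O)OCc4ccccc4)CC3)nn2)cc(OC)c1OC` is not yet measured; its change from compound 2 is 3,4,5-trimethoxyphenyl in place of 4-chlorophenyl on a saturated chain carbon bound to an aromatic nitrogen. For the measured compounds named here, the single measured step concerns a chloro on the same ring and bears only loosely here: compound 3 keeps no chlorine at all and instead carries methoxy groups. With no closer guide, a small step weakening inhibition, near the edge of the scatter, is expected, a 1.1-fold higher number from compound 2 to compound 3 (0.04 log units; within the scatter). Compound 3 is estimated at 30000 nM in this assay, with a range from 10000 nM to 90000 nM.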

Compound 3, half-maximal inhibitory concentration: > 128000 nM
Compound 3: a limit, no number; the forecaster's own chance of this, stated with the estimate: 15%; middle value at least 4.2-fold (0.63 log units) from the limit.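

Compound 3 gives a limit of the assay, not a number: the limit of > 128000 nM in this assay, at which 1 of the 3 values shown sits. Replacing 4-chlorophenyl with 3,4,5-trimethoxyphenyl on this saturated chain carbon gives an at least 4.6-fold higher number from compound 2 to compound 3 (0.66 log units; beyond the scatter), and replacing 3,4-dichlorophenyl with the same group gives an at least 12-fold higher number from compound 1 to compound 3 (1.08 log units; beyond the scatter). The earlier pair showed only what one chloro changes, whereas these steps show that a change of ring substituents at this position can weaken inhibition much further, with both chloro-bearing rings giving stronger inhibition than the trimethoxy ring.

The compounds shown do not separate the loss of chloro from the arrival of the methoxy groups, as both happen in the same step. On these data alone, how a phenyl ring with a single methoxy group, or one carrying an amine or a carboxylic acid, would behave here remains open.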